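Bromo for trifluoromethyl on the benzyl ring of compound 2

This account rests on a few compounds, and the source may have more. Where it says the series, first, only, none or still open, it means among the compounds named here.

Working notes on three measured compounds and one open one in an assay for inhibition of Indoleamine 2,3-dioxygenase 1 (Homo sapiens), with stated times of 10 min and 60 min, tested at 10 uM; a lower number here means a weaker effect, a higher number a stronger effect of the compound at the concentration tested. Compound 1 `O=C1NC(=O)c2c(NCc3ccccc3[N+](=O)[O-])cccc21` gives 11% in this assay. Compound 3 `O=[N+]([O-])c1ccccc1CNc1cc(Br)cc2[nH]ncc12` gives 67% in this assay. Compound 2 `FC(F)(F)c1cccc(CNc2cc(C(F)(F)F)cc3[nH]ncc23)c1` gives 25% in this assay and so stands second highest of the three numbers: compound 1 is its nearest neighbour and lies lower, beyond the scatter, while compound 3 is furthest and lies higher, also beyond the scatter.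

Compound 4 `FC(F)(F)c1cc(NCc2cccc(Br)c2)c2cn[nH]c2c1` has not yet been measured. It differs from compound 2 by bromo in place of trifluoromethyl on an aromatic carbon, the exchange sitting on an aromatic carbon of a six-membered aromatic ring of carbon only, meta to a large group. Going by the values given here, no measured pair in the set shows this single change, and compound 3 differs from compound 2 in more than one place, so no step size can be read off. Against that background the step of a number 5 percentage points higher from compound 2 to compound 4 (within the scatter) is expected to be small, not clearly beyond the scatter in either direction. Compound 4 is therefore expected to give about 30% in this assay, within a range of 10% to 55%.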

Compound 4, a percentage reported as inhibition, at one concentration (the size of the read-out at that concentration, not a potency): 23%
Compound 4: the middle estimate sits 7 percentage points above what was measured; the range from low to high includes it.
By their numbers in this assay, from the lowest: compound 1; then compounds 4 and 2 (each within the scatter of the next); then compound 3.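

In this assay, bromo in place of trifluoromethyl on an aromatic carbon of a six-membered aromatic ring of carbon only, meta to a large group, gives a number 2 percentage points lower from compound 2 to compound 4 (within the scatter). Going by these compounds alone, this is the first step that changes one place only, and it shows that exchanging a group of 4 heavy atoms for one of 1 heavy atom at this position leaves the two compounds indistinguishable in this read-out. No measurement here gives a reason for this outcome.

Still open, on these data alone, is whether another group at this position, such as an amine, a carboxylic acid or a longer chain, would produce a step beyond the scatter. Compound 3, at 67%, differs from compound 4 in more than one place, so the steps that would account for that value cannot be read.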